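This account rests on a few compounds, and the source may have more. Where it says the series, first, only, none or still open, it means among the compounds named here.

Measured in a functional assay on the whole organism (strain Sprague-Dawley) for inhibition, with Rattus norvegicus as the target; on this read-out lower numbers stand for an effect already at smaller amounts and higher numbers for an effect only at larger amounts of compound:
Compound 1 `O=C(O)c1cnc2c(F)cccc2c1` gives 150 mg/kg.
Compound 2 `CCc1ccc2c(=O)c(-c3nn[nH]n3)c[nH]c2c1` gives only a limit, > 10 mg/kg.
Compound 3 `O=C(O)c1cnc2c(Cl)cccc2c1` gives 150 mg/kg.

Compound 2 thus stands at the limit of > 10 mg/kg in this assay, at which 1 of the 3 values shown sits, so no number is known for it, only that it lies beyond this limit. Compound 4 `O=c1c(-c2nn[nH]n2)c[nH]c2ccccc12` differs from it by hydrogen in place of ethyl on an aromatic carbon. Among the compounds with values here, no measured step touches this kind of change: the only step recorded, no change at the digits printed from compound 1 to compound 3 (within the scatter), swaps one halogen for another on a different core and says nothing about removing an ethyl group. The expectation for this assay is therefore set only by the limit of compound 2, with no direction beyond the scatter claimed. Compound 4 is expected at 100 mg/kg, in a range from 20 mg/kg to 400 mg/kg. The step that the limit leaves unreadable from compound 2 to compound 4 is the expected shift this estimate implies.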

Compound 4, minimum effective dose: > 20 mg/kg
Compound 4: only a limit was reported (the forecaster's own chance of this, stated with the estimate: 70%); the middle value lies beyond the limit too.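

Compound 2 and compound 4 each give only a limit, so the step between them cannot be read. The compounds shown leave open what hydrogen in place of ethyl does to the minimum effective dose.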